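The source may report more compounds than this note shows. Statements on the series, on what has been measured and on what is new or still open speak of the compounds shown alone.

Compound 2, with the structure `CSc1nnc(Cc2ccccc2Oc2ccccc2)[nH]1`, stands lowest of the two numbers measured in a functional assay on the whole organism (strain NMRI) with Mus musculus as the target, with a stated time of 60 min, at a dose of 10 mg/kg by the intraperitoneal route (on this read-out lower numbers stand for a weaker effect and higher numbers for a stronger effect at the one dose given), where compound 2 gives 133%. Among the compounds with values here, its only neighbour, compound 1, with the structure `S=c1[nH]nc(Cc2ccccc2Oc2ccccc2)[nH]1`, gives in this assay 142%, and the step of a number 9 percentage points lower from compound 1 to compound 2 (within the scatter) stays within the scatter. Compound 3, with the structure `Nc1nnc(Cc2ccccc2Oc2ccccc2)o1`, has not been measured in this assay; compared with compound 2 the change is a group of 6 heavy atoms (2 carbon, 3 nitrogen, 1 oxygen; one five-membered aromatic ring with 3 hetero atoms) in place of a group of 7 heavy atoms (3 carbon, 3 nitrogen, 1 sulfur; one five-membered aromatic ring with 3 hetero atoms), on a saturated chain carbon bound to an aromatic carbon. Within the data shown here, the one measured step bearing on this place, a number 9 percentage points lower from compound 1 to compound 2 (within the scatter), swapped a group of seven heavy atoms for a group of six at the same saturated chain carbon without leaving the scatter, so a swap of the same size at the same place, now with an oxygen in the ring in place of sulfur, is expected to produce no step beyond the scatter either. The step of a number 3 percentage points lower from compound 2 to compound 3 (within the scatter) is therefore the expected one, and compound 3 is estimated at 130%, in a range from 100% to 160%.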

Compound 3, a percentage reported as activity, at one dose (the size of the read-out at that dose, not a potency): 143%
Estimate against measurement, compound 3: 13 percentage points below; the range from low to high includes it.
By their numbers in this assay, from the lowest: compounds 2, 1 and 3 (each within the scatter of the next).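

In this assay, the 5-amino-1,3,4-oxadiazol-2-yl group, on a saturated chain carbon bound to an aromatic carbon, gives a number 10 percentage points higher from compound 2 to compound 3 (within the scatter) and a number 1 percentage points higher from compound 1 to compound 3 (within the scatter). This extends what the earlier pair showed: at this place, the change can also remove sulfur from the group altogether and bring oxygen into the ring, and all three compounds still read alike at the one dose given. No measurement at hand bears on why the three groups read alike.

On these data alone, whether a carboxylic acid or a simple amine on the same saturated chain carbon, with no five-membered aromatic ring there, would keep this read-out stays open. As far as these compounds go, the read-out gives only the size of the effect at the one dose given, so how the effects of compound 1, compound 2 and compound 3 would compare at any other dose stays open too.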